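Extending the Chain on a Toll-like Receptor 8 Agonist Core

This account rests on a few compounds, and the source may have more. Where it says the series, first, only, none or still open, it means among the compounds named here.

Of the compounds shown here, three sharing one core have been measured in an assay on HEK293 cells for agonist activity at Toll-like receptor 8 (Homo sapiens), read by spectrophotometry; on this read-out higher numbers stand for an effect only at larger amounts of compound and lower numbers for an effect already at smaller amounts. Compound 1 `CCCCNc1nc(N)nc(C)c1C` gives 3280 nM. Compound 2 `CCCCNc1nc(N)nc(C)c1CCCC` gives 780 nM, and compound 3 `CCCCNc1nc(N)nc(C)c1CCc1ccccc1` gives 1190 nM. Compound 2 shows the lowest number of the three: its gap to compound 3 stays within the scatter (a 1.5-fold higher number from compound 2 to compound 3 (0.18 log units; within the scatter)), whereas the step of a 4.2-fold lower number from compound 1 to compound 2 (0.62 log units; beyond the scatter) lies beyond it. Compound 4 `CCCCNc1nc(N)nc(C)c1CCCN1CCN(C)CC1` differs from compound 2 by 4-methylpiperazin-1-yl in place of methyl on a saturated chain carbon, three bonds along the chain from an aromatic carbon. For the measured compounds named here, no measured step touches that outer position: a 2.8-fold lower number from compound 1 to compound 3 (0.44 log units; beyond the scatter) concerns the first chain carbon, and the swap further along the chain stayed within the scatter. Little movement is therefore expected, and the estimated step is a 1.1-fold lower number from compound 2 to compound 4 (0.05 log units; within the scatter). Compound 4 is expected near 700 nM, within 250 nM to 2000 nM.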

Compound 4, half-maximal effective concentration: 179 nM
For compound 4 the middle estimate is 3.9-fold (0.59 log units) above the measured one; measured number outside the range, below it.
By their numbers in this assay, from the lowest: compound 4; then compounds 2 and 3 (each within the scatter of the next); then compound 1.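

The outer end of the chain is not a silent position: 4-methylpiperazin-1-yl in place of methyl, three bonds along the chain from an aromatic carbon, gives a 4.4-fold lower number from compound 2 to compound 4 (0.64 log units; beyond the scatter) and so moves the number beyond the scatter. For the compounds shown here, the earlier swap further along this chain, phenyl in place of ethyl, stayed within the scatter, so this is the first sign that a change this far out can matter. Nothing measured here gives a reason for the step. Which part of the group carries the step stays open: a morpholine, a piperidine or a plain dimethylamino group at the same place would help separate the ring from its nitrogens.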